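Cytotoxicity Expected for a Cyanoethenyl Analogue

The compounds below may be only part of what the source reports. "The series", "measured", "known", "first", "only" and "open" are said of these compounds alone.

Measured compounds:
- compound 1 `Cc1cc(CCC#N)cc(C)c1Oc1cc(Nc2ccc(C#N)cc2)c(N)cc1C(N)=O`: > 9400 nM
- compound 2 `Cc1cc(CCC#N)cc(C)c1Oc1cc(Nc2ccc(C#N)cc2)c(N)cc1N`: > 25000 nM

In an ADME assay on TZM cells (Homo sapiens) for cytotoxicity, read by XTT assay, with a stated time of 4 days (on this read-out higher numbers stand for lower toxicity in this test and lower numbers for higher toxicity in this test), compound 1 gives > 9400 nM, which is a limit of the assay rather than a number. Compound 2 gives > 25000 nM in this assay, again a limit. Among the compounds with values here, both values therefore sit at the limit of > 25000 nM in this assay, at which 1 of the 2 values shown sits, or (the limit of > 9400 nM in this assay, at which 1 of the 2 values shown sits), and the one measured step, a step that the two limits leave unreadable from compound 1 to compound 2, cannot be sized from them. Compound 1 stands, on these numbers, as a compound whose toxicity was too low to be pinned down within the tested range.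

Compound 3 `Cc1cc(/C=C/C#N)cc(C)c1Oc1cc(Nc2ccc(C#N)cc2)c(N)cc1C(N)=O` differs from compound 1 by 2-cyanoethenyl in place of 2-cyanoethyl on an aromatic carbon. Within the data shown here, no measured step bears on this particular change, and the only step recorded concerns a different group and is itself unreadable, so no direction of change in this assay can be drawn from the data. Compound 3 is expected to give about 15000 nM in this assay, with a range from 5000 nM to 50000 nM, and is expected most likely to be reported once more as a limit. The expected step that the limit leaves unreadable from compound 1 to compound 3 is estimated to be nothing beyond the scatter.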

Compound 3, half-maximal cytotoxic concentration in the TZM assay: > 23600 nM
Compound 3: a limit, no number (the forecaster's own chance of this, stated with the estimate: 70%); middle value at least 1.5-fold (0.19 log units) away from the limit.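

Within the data shown here, in the TZM assay, compound 1 and compound 3 are both reported only as limits of the assay, not as numbers, so no step between them can be read. In a physicochemical assay for solubility, with a stated time of 4 h, at pH 2.0 (a lower number here means a less soluble compound, a higher number a more soluble compound), compound 1 gives 9.11 ug/mL and compound 3 gives 2.09 ug/mL. In the physicochemical assay this is a 4.4-fold lower number from compound 1 to compound 3 (0.64 log units; beyond the scatter). The compounds shown leave open whether 2-cyanoethenyl in place of 2-cyanoethyl changes cytotoxicity at all.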